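The source may report more compounds than this note shows. Statements on the series, on what has been measured and on what is new or still open speak of the compounds shown alone.

Compound 1 `CC(=O)N(C)c1ccc2c(c1)CCN2c1cc(OC2CCN(c3nc(C(C)C)no3)CC2)ncn1`: 3.7
Compound 2 `CC(C)c1noc(N2CCC(Oc3cc(N4CCc5cc(N6CCC(O)CC6=O)ccc54)ncn3)CC2)n1`: 2.8
Compound 3 `CC(C)c1noc(N2CCC(Oc3cc(N4CCc5cc(N6CCCC6=O)ccc54)ncn3)CC2)n1`: 3.7

In a physicochemical assay for lipophilicity, measured as octanol-water partition, at pH 7.4 (on this read-out lower numbers stand for lower lipophilicity and higher numbers for higher lipophilicity), compound 3 stands level with compound 1 at the digits shown, and the two share the highest reading of the three. Against compound 1 the step is no change at the digits printed from compound 1 to compound 3 (within the scatter); compound 2 is the furthest away, the step being a number 0.90 log units higher from compound 2 to compound 3 (beyond the scatter).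

Compound 4 `CC(C)c1noc(N2CCC(Oc3cc(N4CCc5cc(N6CCCS6(=O)=O)ccc54)ncn3)CC2)n1` has not yet been measured. It differs from compound 3 in one place: a group of 7 heavy atoms (3 carbon, 1 nitrogen, 2 oxygen, 1 sulfur; one five-membered non-aromatic ring with 2 hetero atoms) in place of a group of 6 heavy atoms (4 carbon, 1 nitrogen, 1 oxygen; one five-membered non-aromatic ring with 1 hetero atom), on an aromatic carbon. Going by the values given here, two measured steps bear on this exchange. From compound 1 to compound 3, acetyl(methyl)amino on an aromatic carbon was replaced by 2-oxopyrrolidin-1-yl, and the result was no change at the digits printed from compound 1 to compound 3 (within the scatter). From compound 2 to compound 3, 4-hydroxy-2-oxopiperidin-1-yl was replaced by 2-oxopyrrolidin-1-yl, giving a number 0.90 log units higher from compound 2 to compound 3 (beyond the scatter). Among the compounds with values here, no measured step brings in a sulfur atom or a second hydrogen-bond acceptor at this position, so the expectation rests on the counted change alone: the entering group carries one more acceptor than the leaving one, and a small decrease is expected, estimated as a number 0.40 log units lower from compound 3 to compound 4 (beyond the scatter). For compound 4 the expected value is 3.3, with a range from 2.8 to 3.8.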

Compound 4, distribution coefficient: 3.2
Estimate against measurement, compound 4: 0.10 log units above; the measured number falls inside the stated range.
By their numbers in this assay, from the lowest: compound 2; then compound 4; then compounds 1 and 3 (each within the scatter of the next).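

In this assay this aromatic carbon now shows a shift that needs no hydroxy group: the five-membered ring with sulfur has no hydrogen-bond donor, nor does the 2-oxopyrrolidin-1-yl it replaces, and the number still drops (a number 0.50 log units lower from compound 3 to compound 4 (beyond the scatter)). Acetyl(methyl)amino and 2-oxopyrrolidin-1-yl read alike, and the sulfur ring parts from the former by the same amount (a number 0.50 log units lower from compound 1 to compound 4 (beyond the scatter)). It does not fall as far as 4-hydroxy-2-oxopiperidin-1-yl (a number 0.40 log units higher from compound 2 to compound 4 (beyond the scatter)), so this position now holds a level between the two seen before.

On these data alone, how an open-chain sulfonamide, an amine or a carboxylic acid on this aromatic carbon would read remains open. Nothing shown here gives a measured explanation for the shift, so the sulfur ring's effect cannot be assigned to any one of its features.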